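The source may report more compounds than this note shows. Statements on the series, on what has been measured and on what is new or still open speak of the compounds shown alone.

In an ADME assay on MT4 cells (Homo sapiens) for cytotoxicity, read by MTT assay, with a stated time of 4 days (a lower number here means that less compound is tolerated, a higher number that more compound is tolerated), compound 2 `Nc1ccc2oc(-c3ccccc3)c(O)c(=O)c2c1` gives 217000 nM while compound 3 `COc1cccc(-c2oc3ccc(N)cc3c(=O)c2O)c1` gives 40800 nM and compound 1 `CC(=O)Nc1ccc2oc(-c3cccc(F)c3)c(O)c(=O)c2c1` gives 26500 nM on the same scale. Compound 3 therefore cannot be told apart from compound 1 and sits well under compound 2. Compound 4 `Nc1ccc2oc(-c3cccc(F)c3)c(O)c(=O)c2c1` differs from compound 3 by a single change, fluoro in place of methoxy (fluoro in place of methoxy on an aromatic carbon). Within the data shown here, the one measured step that bears on it is a 5.3-fold lower number from compound 2 to compound 3 (0.73 log units; beyond the scatter) when methoxy replaced hydrogen. Removing methoxy might take back part of that step, but compound 1, which also carries fluoro, gives 26500 nM and shows no sign of a large rise. A small rise is expected (a 1.3-fold higher number from compound 3 to compound 4 (0.13 log units; within the scatter)) and nothing clearly beyond the scatter. The estimate for compound 4 is 55000 nM with an expected range from 20000 nM to 140000 nM in this assay.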

Compound 4, half-maximal cytotoxic concentration: 35300 nM
The estimate for compound 4 lay 1.6-fold (0.19 log units) above the measured number, and the stated range covers the measured number.
By their numbers in this assay, from the lowest: compounds 1, 4 and 3 (each within the scatter of the next); then compound 2.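

In this assay, fluoro and methoxy on this aromatic carbon cannot be told apart, with a 1.2-fold lower number from compound 3 to compound 4 (0.06 log units; within the scatter). Fluoro in place of hydrogen gives a 6.1-fold lower number from compound 2 to compound 4 (0.79 log units; beyond the scatter), so the lower number seen earlier with methoxy, a 5.3-fold lower number from compound 2 to compound 3 (0.73 log units; beyond the scatter), is not unique to methoxy. Acetyl on the ring nitrogen makes no clear difference either, with a 1.3-fold higher number from compound 1 to compound 4 (0.12 log units; within the scatter). No measured property here explains why either group lowers the number relative to hydrogen. Going by these compounds, whether chloro, an amine or a carboxylic acid on this carbon would also give a lower number remains open.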